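Compound 4: hydrogen in place of the cyanophenyl group

The compounds below may be only part of what the source reports. "The series", "measured", "known", "first", "only" and "open" are said of these compounds alone.

Three analogues share one core and differ only in the group on a saturated chain carbon bound to an aromatic nitrogen. In a functional assay on the whole organism (B cells) with Mus musculus as the target (a higher number here means a larger maximal response, a lower number a smaller maximal response), compound 1 `Nc1nc(O)c2c(n1)n(C1OC(CO)[C@@H](O)[C@H]1O)c(=O)n2Cc1ccc(Cl)c(Cl)c1` gives 55%, compound 2 `Nc1nc(O)c2c(n1)n(C1OC(CO)[C@@H](O)[C@H]1O)c(=O)n2Cc1ccc([N+](=O)[O-])cc1` gives 147%, and compound 3 `N#Cc1cccc(Cn2c(=O)n(C3OC(CO)[C@@H](O)[C@H]3O)c3nc(N)nc(O)c32)c1` gives 16%, the lowest of the three. The steps at this position are all large: a number 92 percentage points higher from compound 1 to compound 2 (beyond the scatter), a number 39 percentage points lower from compound 1 to compound 3 (beyond the scatter) and a number 131 percentage points lower from compound 2 to compound 3 (beyond the scatter). Compound 4 `Cn1c(=O)n(C2OC(CO)[C@@H](O)[C@H]2O)c2nc(N)nc(O)c21` carries the change (hydrogen in place of 3-cyanophenyl on a saturated chain carbon bound to an aromatic nitrogen). The measured steps at this place bear on it, but each only swaps one aryl group for another; none removes the whole aryl group, so the direction of the step is not fixed by the data, and a large step in either direction remains possible. The estimate for compound 4 is 40%, with an expected range of 5% to 120%. This corresponds to an expected step of a number 24 percentage points higher from compound 3 to compound 4 (beyond the scatter).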

Compound 4, largest response reached (reported as maximal response), in percent of the reference or control that the assay uses: 99%
Compound 4: the middle estimate sits 59 percentage points below what was measured, within the range that was stated.
By their numbers in this assay, from the lowest: compound 3; then compound 1; then compound 4; then compound 2.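

In this assay, the step from the 3-cyanobenzyl or 3,4-dichlorobenzyl group to methyl raises the response (a number 83 percentage points higher from compound 3 to compound 4 (beyond the scatter); a number 44 percentage points higher from compound 1 to compound 4 (beyond the scatter)), whereas the same kind of change from the 4-nitrobenzyl group lowers it (a number 48 percentage points lower from compound 2 to compound 4 (beyond the scatter)). The aryl group is therefore not needed for a substantial response, and removing it has no single direction across these compounds. Nothing available here explains these differences.

Going by these compounds, whether an ethyl group or a longer chain would stay closer to compound 4 remains open. Also open, on these data alone, is how an amine or a carboxylic acid on the phenyl ring would compare with the nitro group of compound 2.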